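Replacing the aryl amide of compound 2 with a pyrrolidinylethyl chain

The compounds below may be only part of what the source reports. "The series", "measured", "known", "first", "only" and "open" are said of these compounds alone.

Three compounds share one core and differ only in the group on the amide nitrogen. Compound 1 `O=C(CCC(=O)OCCCCCCSc1ccc([N+](=O)[O-])c2nonc12)Nc1cccc(Cl)c1` gives 1100 nM in an assay on isolated protein for inhibition of glutathione S-transferase Mu 2 (Homo sapiens), with a stated time of 10 min; a higher number here means a weaker inhibitor, a lower number a stronger inhibitor; compound 3 `O=C(CCC(=O)OCCCCCCSc1ccc([N+](=O)[O-])c2nonc12)Nc1ccc(F)c(Cl)c1` gives 470 nM; compound 2 `O=C(CCC(=O)OCCCCCCSc1ccc([N+](=O)[O-])c2nonc12)Nc1ccc(Br)cc1` gives 32000 nM, the highest of the three numbers, so compound 2 is the weakest inhibitor here, with a 29-fold higher number from compound 1 to compound 2 (1.46 log units; beyond the scatter) and a 68-fold lower number from compound 2 to compound 3 (1.83 log units; beyond the scatter) both well beyond the scatter. Compound 4 `O=C(CCC(=O)OCCCCCCSc1ccc([N+](=O)[O-])c2nonc12)NCCN1CCCC1` is the next step from compound 2: 2-(pyrrolidin-1-yl)ethyl in place of 4-bromophenyl on an amide-type nitrogen. The two measured steps that change this same group were large in both cases, which shows that this position governs the number strongly, but neither step exchanges an aryl group for a 2-(pyrrolidin-1-yl)ethyl chain, so no direction can be read from them. The expectation for compound 4 therefore stays near compound 2 with a wide range, estimated at 25000 nM (range 4000 nM to 150000 nM). That estimate means a step of a 1.3-fold lower number from compound 2 to compound 4 (0.11 log units; within the scatter), expected to lie within the scatter.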

Compound 4, half-maximal inhibitory concentration: 200 nM
For compound 4 the middle estimate is 130-fold (2.10 log units) above the measured one; measured number outside the range, below it.
By their numbers in this assay, from the lowest: compound 4; then compound 3; then compound 1; then compound 2.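

In this assay, the step of a 160-fold lower number from compound 2 to compound 4 (2.20 log units; beyond the scatter) shows that an aromatic ring on the amide-type nitrogen is not needed for a low number, since 2-(pyrrolidin-1-yl)ethyl replaces 4-bromophenyl here. The change also holds up against the better aryl amides, with a 2.4-fold lower number from compound 3 to compound 4 (0.37 log units; beyond the scatter) and a 5.5-fold lower number from compound 1 to compound 4 (0.74 log units; beyond the scatter), which makes compound 4 the strongest inhibitor of the four. The compounds shown give no evidence for why this exchange lowers the number so far.

Compound 4 is the only compound shown with a non-aromatic group at this position, so it cannot be told whether the pyrrolidine ring, the ethyl chain or their combination accounts for the result. A morpholine ring or a dimethylamino group in place of the pyrrolidine, or a propyl chain in place of the ethyl, remains an open case.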